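Pyridine in Place of Phenyl on the Shared Core

The source may hold more compounds than are shown below. What is called first, only, known or untested is meant among the compounds shown, and "the series" means these compounds.

Of the compounds shown here, two have been measured in a functional assay on HCT-116 cells (Homo sapiens) for cytotoxicity; a higher number here means a weaker inhibitor, a lower number a stronger inhibitor. Compound 1 `COc1ccc(C2=C(c3ccncc3)C(=O)N3CCCC3C2)cc1` gives 19000 nM. Compound 2 `CSc1ccc(C2=C(c3ccccc3)C(=O)N3CCCC3C2)cc1` gives 1000 nM, the lower of the two numbers, though the two structures differ in two places at once, so no single change accounts for the gap. Compound 3 `CSc1ccc(C2=C(c3ccncc3)C(=O)N3CCCC3C2)cc1` is still unmeasured; it differs from compound 2 by pyridin-4-yl in place of phenyl on a double-bonded ring carbon. Going by the values given here, no measured pair isolates this change. A weakening step is expected, around a 5.0-fold higher number from compound 2 to compound 3 (0.70 log units; beyond the scatter), because compound 1 with the same pyridin-4-yl group gives 19000 nM in this assay. Compound 3 is therefore estimated at 5000 nM, within 1500 nM to 20000 nM.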

Compound 3, half-maximal inhibitory concentration: 6000 nM
Compound 3: the middle estimate sits 1.2-fold (0.08 log units) below what was measured; low and high end bracket the measured number.
By their numbers in this assay, from the lowest: compound 2; then compound 3; then compound 1.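

In this assay, pyridin-4-yl in place of phenyl on the double-bonded ring carbon now has its own measured cost (a 6.0-fold higher number from compound 2 to compound 3 (0.78 log units; beyond the scatter)) with the 4-(methylsulfanyl)phenyl group held fixed. The other difference can also be read alone, since methylsulfanyl in place of methoxy on an aromatic carbon, with pyridin-4-yl held fixed, goes the opposite way (a 3.2-fold lower number from compound 1 to compound 3 (0.50 log units; beyond the scatter)). Nothing available explains why either step occurs.

Still open, as far as these compounds go, is whether a pyridin-3-yl or aminophenyl group at this carbon would track phenyl or pyridin-4-yl, and how ethylsulfanyl, a longer chain on the sulfur, would compare with methylsulfanyl.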